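Removing a Methyl From an Aromatic Nitrogen: Expected Potency

A few compounds are considered here, and "the series" means these few. Any claim that something is new, unique, unknown or untested is made for them only; others in the source may bear on it.

Measured so far:
- compound 1 `COc1ccccc1/C=c1/[nH]c(=O)/c(=C\c2ccccc2OC)n(C)c1=O`: in a functional assay on HL-60 cells (Homo sapiens) for cytotoxicity, read by CCK-8 assay, with a stated time of 72 h (a higher number here means a weaker inhibitor, a lower number a stronger inhibitor), compound 1 gives 16200 nM
- compound 2 `C=CCn1c(=O)/c(=C\c2ccc(Cl)c(Cl)c2)[nH]c(=O)/c1=C\c1ccccc1`: compound 2 gives "not active" (no number reported)
- compound 3 `C=CCn1c(=O)/c(=C\c2cc(F)ccc2C)[nH]c(=O)/c1=C\c1ccccc1OC`: compound 3 gives 2600 nM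

Compound 1 stands at the highest of the two numbers reported, so it is the weaker of the two compounds with a number; compound 3 gives the lower number, and that gap lies beyond the usual scatter. Compound 2 gave no number at all.

Compound 4 `COc1ccccc1/C=c1/[nH]c(=O)/c(=C\c2ccccc2OC)[nH]c1=O` differs from compound 1 in one place: hydrogen in place of methyl on an aromatic nitrogen. Among the measured compounds shown here, no pair among the measured compounds isolates this same change, so nothing here shows how large such a step tends to be in this assay.

Without such a reference, the expected step from compound 1 to compound 4, a 1.0-fold lower number from compound 1 to compound 4 (0.01 log units; within the scatter), is none beyond the scatter, with a wide range allowed in both directions. Compound 4 is therefore estimated at 16000 nM, between 5000 nM and 50000 nM.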

Compound 4, half-maximal inhibitory concentration: "not active" (no number reported)
The entry for compound 4 holds no number; there is nothing to compare the estimate with.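

Among the compounds shown here, compound 4 is reported as not active in this assay, without a number, so no step from compound 1 to compound 4 can be read. The compounds shown leave open how far replacing methyl with hydrogen on the aromatic nitrogen shifts potency. Nothing measured here offers an explanation for this result.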